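A Methyl Added Far Out on a Side Chain

The source may report more compounds than this note shows. Statements on the series, on what has been measured and on what is new or still open speak of the compounds shown alone.

Compound 1, `CCc1cc(C(C)=O)c(OCc2ccccc2)cc1OCCCCCC(C)(C)c1nnn[nH]1`, and compound 2, `CCc1cc(C(C)=O)c(OC(C)c2ccccc2)cc1OCCCCCC(C)(C)c1nnn[nH]1`, share one core and differ by a single methyl group. In an assay on isolated protein for antagonist activity at Bile acid receptor (Homo sapiens), read by HTRF, with a stated time of 30 min (a higher number here means a weaker inhibitor, a lower number a stronger inhibitor), compound 1 gives 1100 nM, and compound 2 gives 1700 nM. The change between them is methyl in place of hydrogen on a saturated chain carbon bound to an aromatic carbon and an oxygen on an aromatic ring and it made a 1.5-fold higher number from compound 1 to compound 2 (0.19 log units; within the scatter), too small a step to count as a real difference between the two.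

Compound 3, `CCCc1cc(C(C)=O)c(O)cc1OCCCCCC(C)(C)c1nnn[nH]1`, is built on another core; how that core differs from the core of compound 1 is not broken down here. In this assay compound 3 gives 25200 nM, the highest of the three numbers, and its distance from each of the other two lies beyond the scatter.

Compound 4, `CC(=O)c1cc(CC(C)C)c(OCCCCCC(C)(C)c2nnn[nH]2)cc1O`, has not yet been measured. It differs from compound 3 by methyl in place of hydrogen on a saturated chain carbon bound to two saturated chain carbons. Going by the values given here, this is the same kind of change as the one from compound 1 to compound 2, but not the same change: there the place was a saturated chain carbon bound to an aromatic carbon and an oxygen on an aromatic ring, here it is a saturated chain carbon bound to two saturated chain carbons.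

The step expected in this assay is a 1.2-fold higher number from compound 3 to compound 4 (0.08 log units; within the scatter), set beside the measured 1.5-fold higher number from compound 1 to compound 2 (0.19 log units; within the scatter), because the earlier change of this kind gave a 1.5-fold higher number from compound 1 to compound 2 (0.19 log units; within the scatter) and nothing among these compounds points to a larger move. Compound 4 is therefore estimated at 30000 nM, with a likely range from 12000 nM to 75000 nM.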

Compound 4, half-maximal inhibitory concentration: 5800 nM
Compound 4: the middle estimate sits 5.2-fold (0.71 log units) above what was measured; measured number below the stated range.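

In this assay, replacing one hydrogen with a methyl turns the propyl chain into an isobutyl chain and gives a 4.3-fold lower number from compound 3 to compound 4 (0.64 log units; beyond the scatter), so this small change matters on this core. The result from the earlier pair did not carry over, and the two steps differ in both direction and size: the same change on two cores in this assay, a 1.5-fold higher number (0.19 log units; within the scatter) from compound 1 to compound 2 and a 4.3-fold lower number (0.64 log units; beyond the scatter) from compound 3 to compound 4, 6.7-fold (0.83 log units) apart, beyond the scatter of two such steps This shows that a methyl step measured on one core was a poor guide to the step on the other, but it does not show why, since the two pairs differ in their cores and in the place where the methyl was added, and two pairs cannot separate those explanations or establish a rule for the series.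

The compounds shown leave open whether the gain from compound 3 to compound 4 depends on the branched shape of the isobutyl chain or simply on the added carbon, a question that an unbranched butyl chain at the same place could help answer. They also leave open whether the same propyl to isobutyl change would give a similar step on the core of compound 1, and what a cyclopropyl ring would do there.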